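The source may report more compounds than this note shows. Statements on the series, on what has been measured and on what is new or still open speak of the compounds shown alone.

Measured so far, all in an in vitro functional assay on SH-EP1 cells for agonist activity at Neuronal acetylcholine receptor; alpha4/beta2 (Homo sapiens), read by FLIPR and calcium flux; a lower number here means that less compound is needed, a higher number that more compound is needed for the effect:

Compound 1 `Fc1ccc(C2=CC3CNCC(C2)C3)cn1` gives 85 nM.
Compound 2 `C1=C(c2cccnc2)C[C@@H]2CNC[C@H]1C2` gives 2.3 nM.
Compound 3 `CN1CC2C=C(c3ccc(F)nc3)CC(C2)C1` gives only a limit of the assay, > 10000 nM.

Of the two numbers that are not limits, compound 2 has the lower one and compound 1 the higher, a gap beyond the usual scatter. How the core of compound 2 differs from the core of compound 1 is not broken down here.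

From compound 1 to compound 3 the change is methyl in place of hydrogen on an amine nitrogen in a ring. It made an at least 110-fold higher number from compound 1 to compound 3 (2.07 log units; beyond the scatter). Since compound 3 sits at the limit of > 10000 nM in this assay, at which 1 of the 3 values shown sits, the full size of that step is not known; only its lower bound is.

Compound 4 `CN1C[C@@H]2C=C(c3cccnc3)C[C@@H](C2)C1` has not yet been measured in this assay. It differs from compound 2 by methyl in place of hydrogen on an amine nitrogen in a ring, the same change as before, and the two places are described in the same words. The step from compound 2 to compound 4 is therefore expected to be a 350-fold higher number from compound 2 to compound 4 (2.54 log units; beyond the scatter), a large one, because the same change made an at least 110-fold higher number from compound 1 to compound 3 (2.07 log units; beyond the scatter). On that basis compound 4 is estimated at 800 nM, with a likely range from 100 nM to 10000 nM. It is also possible that compound 4, like compound 3, will be reported only as a limit rather than a number.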

Compound 4, half-maximal effective concentration: 6660 nM
Estimate against measurement, compound 4: 8.3-fold (0.92 log units) below; the range from low to high includes it.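

In this assay methyl in place of hydrogen on an amine nitrogen in a ring gave a 2900-fold higher number from compound 2 to compound 4 (3.46 log units; beyond the scatter) and so went the same way as on the core of compound 1, with both steps large and beyond the scatter. Set side by side, the two steps read: the same change on two cores in this assay, an at least 110-fold higher number (2.07 log units; beyond the scatter) from compound 1 to compound 3 and a 2900-fold higher number (3.46 log units; beyond the scatter) from compound 2 to compound 4; the limit leaves it open whether they differ. For compound 3 the assay gives only the limit > 10000 nM and no number, so the two cores show that the direction of the change carried over from one to the other, but they do not show whether its size did.

The compounds shown carry only hydrogen or methyl on that nitrogen, so it stays open what an ethyl group or a longer chain would do there, and whether the number would keep rising with the size of the group. As far as these compounds go, it also stays open how the same step would run on a core bearing a chlorine atom in place of the fluorine of compound 1.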